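This account rests on a few compounds, and the source may have more. Where it says the series, first, only, none or still open, it means among the compounds named here.

Compound 1, `COc1cccc(-c2cccc(NC(=O)CCc3ccc4c(c3)COB4O)c2)c1`, is the starting point of this series. In a functional assay on MDA-MB-231 cells (Homo sapiens) for antiproliferative activity, read by MTT assay, with a stated time of 72 h (on this read-out lower numbers stand for stronger inhibition and higher numbers for weaker inhibition), compound 1 gives 90000 nM. Compound 2, `COc1cc(OC)cc(-c2cccc(NC(=O)CCc3ccc4c(c3)COB4O)c2)c1`, carries one change relative to compound 1, (methoxy in place of hydrogen on an aromatic carbon). In this assay compound 2 gives 77000 nM, and the step from compound 1 to compound 2 is a 1.2-fold lower number from compound 1 to compound 2 (0.07 log units; within the scatter). Compound 3, `COc1cccc(-c2cccc(NC(=O)CCc3cccc4c3COB4O)c2)c1`, has the same atoms as compound 1 joined differently; the difference between the two cores is not broken down here. In this assay compound 3 gives 76000 nM, a number that sits within the scatter of the values of compound 1 and compound 2, so no order among the three can be drawn.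

Compound 4, `COc1cc(OC)cc(-c2cccc(NC(=O)CCc3cccc4c3COB4O)c2)c1`, has not been measured. It differs from compound 3 by methoxy in place of hydrogen on an aromatic carbon, the same change that separates compound 1 from compound 2, at a place described in identical words. Because a 1.2-fold lower number from compound 1 to compound 2 (0.07 log units; within the scatter), the same change is expected to give a 1.2-fold lower number from compound 3 to compound 4 (0.07 log units; within the scatter), a step within the scatter. On that basis compound 4 is estimated to give 65000 nM in this assay. Within the data shown here, for compound 4 the estimate is expected to fall between 30000 nM and 150000 nM, with the single earlier example of this change and the small size of its step as the only support.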

Compound 4, half-maximal inhibitory concentration: 93000 nM
Compound 4: middle estimate off by 1.4-fold (0.16 log units), on the low side; low and high end bracket the measured number.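

In this assay, the change from 3-methoxyphenyl to 3,5-dimethoxyphenyl on the core of compound 3 gives a 1.2-fold higher number from compound 3 to compound 4 (0.09 log units; within the scatter). Exchanging the core while keeping the 3,5-dimethoxyphenyl group gives a 1.2-fold higher number from compound 2 to compound 4 (0.08 log units; within the scatter), so the core exchange has no readable effect on this pair either. Set side by side, the two instances of the methoxy change do not differ beyond what repeated measurement allows: the same change on two cores in this assay, a 1.2-fold lower number (0.07 log units; within the scatter) from compound 1 to compound 2 and a 1.2-fold higher number (0.09 log units; within the scatter) from compound 3 to compound 4, 1.4-fold (0.16 log units) apart, within the scatter of two such steps. This shows that, across these two cores, nothing in the data separates the methoxy step on one core from the same step on the other, but it does not show that an effect of the change carries over, as neither step can be told from the scatter and the signs of the two steps cannot be read as a reversal.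

The compounds shown therefore leave open whether any substituent on this ring can move the number beyond the scatter in this assay, for example an amine or a carboxylic acid in place of methoxy. They also leave open whether a longer chain between the carbonyl and the core would do so, and whether the two cores would then behave alike.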